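Benzyl-substituted adenosine analogues against HL-60 proliferation

A few compounds are considered here, and "the series" means these few. Any claim that something is new, unique, unknown or untested is made for them only; others in the source may bear on it.

Measured compounds:
compound 1, `OC[C@H]1O[C@@H](n2cnc3c(NCc4ccccc4Br)ncnc32)[C@H](O)[C@@H]1O`: 6600 nM
compound 2, `Cc1cccc(CNc2ncnc3c2ncn3[C@@H]2O[C@H](CO)[C@@H](O)[C@H]2O)c1`: 6400 nM
compound 3, `OC[C@H]1O[C@@H](n2cnc3c(NCc4ccc(F)c(F)c4F)ncnc32)[C@H](O)[C@@H]1O`: 13000 nM

In a functional assay on HL-60 cells (Homo sapiens) for antiproliferative activity, with a stated time of 72 h (on this read-out higher numbers stand for weaker inhibition and lower numbers for stronger inhibition), compound 1 gives 6600 nM, the second highest of the three numbers. Its nearest neighbour is compound 2, with a 1.0-fold lower number from compound 1 to compound 2 (0.01 log units; within the scatter); its furthest is compound 3, with a 2.0-fold higher number from compound 1 to compound 3 (0.29 log units; within the scatter). For the measured compounds named here, the only step beyond the scatter among the three is a 2.0-fold higher number from compound 2 to compound 3 (0.31 log units; beyond the scatter), and even that is modest.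

Compound 4, `COc1cccc(CNc2ncnc3c2ncn3[C@@H]2O[C@H](CO)[C@@H](O)[C@H]2O)c1O`, has not yet been measured. It differs from compound 1 as follows: 2-hydroxy-3-methoxyphenyl in place of 2-bromophenyl on a saturated chain carbon bound to a nitrogen on an aromatic ring. The three measured steps all exchange the aryl group on the saturated chain carbon bound to a nitrogen on an aromatic ring, and each moves the number little, so they bear directly on this change. Compound 4 is therefore expected to stay close to compound 1 in this assay, with a 1.2-fold higher number from compound 1 to compound 4 (0.08 log units; within the scatter) no more than a small shift, most likely toward a weaker read-out. The estimate for compound 4 is 8000 nM, within a range of 3000 nM to 25000 nM.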

Compound 4, half-maximal inhibitory concentration: 150 nM
Compound 4: the middle estimate sits 53-fold (1.73 log units) above what was measured, outside the stated range (below it).
By their numbers in this assay, from the lowest: compound 4; then compounds 2, 1 and 3 (each within the scatter of the next, the first and the last beyond it).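

In this assay, the aryl group on a saturated chain carbon bound to a nitrogen on an aromatic ring turns out to govern the number far more strongly than the earlier exchanges among 2-bromophenyl, 3-methylphenyl and 2,3,4-trifluorophenyl had shown: 2-hydroxy-3-methoxyphenyl gives a 44-fold lower number from compound 1 to compound 4 (1.64 log units; beyond the scatter), a 43-fold lower number from compound 2 to compound 4 (1.63 log units; beyond the scatter) and an 87-fold lower number from compound 3 to compound 4 (1.94 log units; beyond the scatter). Compound 4 is thus the most potent of the four, and its aryl group, unlike 2-bromophenyl, carries oxygen atoms, a hydrogen-bond donor and hydrogen-bond acceptors. No measurement at hand accounts for this large gain.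

As far as these compounds go, it remains open whether the hydroxy group or the methoxy group alone on the phenyl ring would keep the gain, or whether both are needed. From the compounds shown here alone, it is equally open whether an amino group or a carboxylic acid in their place would do the same.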